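Working notes: methyl-for-hydrogen step, compound 3 to compound 4

The source may hold more compounds than are shown below. What is called first, only, known or untested is meant among the compounds shown, and "the series" means these compounds.

Measured so far in an assay on isolated protein for agonist activity at Bile acid receptor (Homo sapiens), read by TR-FRET, with a stated time of 3 h, in the absence of a further agent; on this read-out lower numbers stand for an effect already at smaller amounts and higher numbers for an effect only at larger amounts of compound:
compound 1, `O=C(O)c1cccc(NC(=O)c2ccc(Oc3ccccc3)cc2)c1`, gives 97 nM
compound 2, `Cc1ccc(NC(=O)c2ccc(Oc3ccccc3)cc2)cc1C(=O)O`, gives 127 nM
compound 3, `O=C(O)c1cccc(NC(=O)c2ccc(OCc3cccc(-c4ccccc4)c3)cc2)c1`, gives 319 nM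

Compound 2 arises from compound 1 by methyl in place of hydrogen on an aromatic carbon; this gave a 1.3-fold higher number from compound 1 to compound 2 (0.12 log units; within the scatter). Compound 3 carries a different core; the difference between the two cores is not broken down here. Compound 4, `Cc1ccccc1-c1cccc(COc2ccc(C(=O)Nc3cccc(C(=O)O)c3)cc2)c1`, is not yet measured; it arises from compound 3 by methyl in place of hydrogen on an aromatic carbon. This is the same kind of change as from compound 1 to compound 2, not the same: in compound 2 the methyl sits ortho to a carboxy group (3 heavy atoms) and para to a large group, whereas in compound 4 it sits ortho to a large group. Because a 1.3-fold higher number from compound 1 to compound 2 (0.12 log units; within the scatter) lay within the scatter, a similarly small step is expected, a 1.3-fold higher number from compound 3 to compound 4 (0.10 log units; within the scatter), with wider uncertainty given the changed surroundings. Compound 4 is therefore estimated at 400 nM, between 160 nM and 1000 nM.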

Compound 4, half-maximal effective concentration: 1030 nM
Compound 4: middle estimate off by 2.6-fold (0.41 log units), on the low side, outside the stated range (above it).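

In this assay, the change from phenyl to 2-methylphenyl gave a 3.2-fold higher number from compound 3 to compound 4 (0.51 log units; beyond the scatter), with the methyl ortho to a large group. Set beside the same change on the core of compound 1, this larger step does not establish a real difference between the two cores: the same change on two cores in this assay, a 1.3-fold higher number (0.12 log units; within the scatter) from compound 1 to compound 2 and a 3.2-fold higher number (0.51 log units; beyond the scatter) from compound 3 to compound 4, 2.5-fold (0.39 log units) apart, within the scatter of two such steps

Two pairs, with the methyl in a different place in each, show neither that the step carries over unchanged nor that it depends on the core. As far as these compounds go, it remains open whether the size of the step on the core of compound 3 follows the place of the methyl on the outer ring. Also open, from the compounds shown here alone, is whether an ethyl, a methoxy or a chlorine there would give a similar step.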